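The compounds below may be only part of what the source reports. "The series", "measured", "known", "first", "only" and "open" are said of these compounds alone.

Working notes on the series.

Two compounds have numbers in an assay on CHO cells for binding affinity to prostaglandin D2 receptor 2 (Homo sapiens); on this read-out lower numbers stand for stronger inhibition and higher numbers for weaker inhibition. Compound 1 `Cc1ccc(S(=O)(=O)n2c(C)c(CC(=O)O)c3cc(F)ccc32)cc1` gives 457 nM in this assay. Within the data shown here, compound 2 `Cc1c(CC(=O)O)c2cc(F)ccc2n1S(=O)(=O)c1cccc(F)c1` gives 225 nM in this assay, the lowest of the two numbers, and the only measured step, a 2.0-fold lower number from compound 1 to compound 2 (0.31 log units; beyond the scatter), separates it from compound 1.

Compound 3 `COc1ccc(S(=O)(=O)n2c(C)c(CC(=O)O)c3cc(F)ccc32)cc1` is not yet measured. It differs from compound 2 by 4-methoxyphenyl in place of 3-fluorophenyl on a sulfonyl sulfur. Among the measured compounds shown here, the one step that bears on this change is the exchange of groups on the sulfonyl sulfur recorded as a 2.0-fold lower number from compound 1 to compound 2 (0.31 log units; beyond the scatter), which runs in the opposite sense: a substituted phenyl with the fluorine replaced by one carrying a 4-methyl group stands at a higher number. Compound 3 carries a 4-methoxyphenyl, a group not yet seen in the series, so its number is expected to lie nearer to that of compound 1 than of compound 2, with a modest rise beyond the scatter rather than a large one. The expected step from compound 2 to compound 3 in this assay is therefore a 1.8-fold higher number from compound 2 to compound 3 (0.25 log units; within the scatter). For compound 3 the estimate in this assay is 400 nM, with a range from 150 nM to 1100 nM.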

Compound 3, inhibition constant: 299 nM
Beside the measured number, compound 3's estimate is 1.3-fold (0.13 log units) above it; the measured number falls inside the stated range.
By their numbers in this assay, from the lowest: compounds 2, 3 and 1 (each within the scatter of the next, the first and the last beyond it).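

In this assay the place on the sulfonyl sulfur now holds a third substituted phenyl, and 4-methoxyphenyl in place of 3-fluorophenyl gives a 1.3-fold higher number from compound 2 to compound 3 (0.12 log units; within the scatter) and so does not separate from the 3-fluorophenyl of compound 2. Methoxy in place of methyl on an aromatic carbon gives a 1.5-fold lower number from compound 1 to compound 3 (0.18 log units; within the scatter) and likewise does not separate compound 3 from compound 1, so compound 3 cannot be ordered against either of them, and the earlier step, a 2.0-fold lower number from compound 1 to compound 2 (0.31 log units; beyond the scatter), remains the only one of the three beyond the scatter. Nothing measured on these compounds accounts for the numbers.

On these data alone, the three groups seen here are all phenyl rings carrying a single fluorine, methyl or methoxy, so it remains open whether the narrow spread in this assay holds for a phenyl carrying an amine or a trifluoromethyl group, or a longer alkoxy chain in place of methoxy. As far as these compounds go, it is equally open what a group other than a substituted phenyl, such as a pyridine ring or a plain alkyl chain, would give on the sulfonyl sulfur of the shared core.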